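Butyl thioether on the shared core: expectation for compound 4

A few compounds are considered here, and "the series" means these few. Any claim that something is new, unique, unknown or untested is made for them only; others in the source may bear on it.

Measured so far in an ADME assay on L929 cells (Mus musculus) for antiproliferative activity, read by CCK-8 assay, with a stated time of 48 h; on this read-out higher numbers stand for weaker inhibition and lower numbers for stronger inhibition:
compound 1 `CC(C)CSc1n[nH]c(-n2[se]c3ccccc3c2=O)n1` gives 33400 nM
compound 2 `O=c1c2ccccc2[se]n1-c1nc(SCc2ccc(Cl)cc2)n[nH]1` gives 39500 nM
compound 3 `Cc1cccc(CSc2n[nH]c(-n3[se]c4ccccc4c3=O)n2)c1` gives > 50000 nM

The value of compound 3 is a limit of the assay, not a number (the limit of > 50000 nM in this assay, at which 1 of the 3 values shown sits). The steps to it read an at least 1.4-fold higher number from compound 1 to compound 3 (0.17 log units; that floor lies within the scatter) and an at least 1.2-fold higher number from compound 2 to compound 3 (0.10 log units; that floor lies within the scatter), so compound 3 stands within the scatter of compounds 1 and 2. Compound 4 `CCCCCSc1n[nH]c(-n2[se]c3ccccc3c2=O)n1` differs from compound 3 by butyl in place of 3-methylphenyl on a saturated chain carbon bound to a sulfur. Within the data shown here, the steps that bear on this position are a 1.2-fold higher number from compound 1 to compound 2 (0.07 log units; within the scatter), an at least 1.4-fold higher number from compound 1 to compound 3 (0.17 log units; that floor lies within the scatter) and an at least 1.2-fold higher number from compound 2 to compound 3 (0.10 log units; that floor lies within the scatter), none beyond the scatter. No change at the saturated chain carbon bound to sulfur has so far moved this assay beyond its scatter, so for compound 4 no step beyond the scatter is expected, an at least 1.2-fold lower number from compound 3 to compound 4 (0.09 log units; that floor lies within the scatter), with the number estimated near compound 1. The estimate for compound 4 is 40000 nM, in the range 20000 nM to 80000 nM.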

Compound 4, half-maximal inhibitory concentration: 33500 nM
Estimate against measurement, compound 4: 1.2-fold (0.08 log units) above, and the stated range covers the measured number.
By their numbers in this assay, from the lowest: compounds 1, 4 and 2 (each within the scatter of the next). At a limit, above all of these: compound 3.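

In this assay, butyl on a saturated chain carbon bound to a sulfur extends the set of groups tolerated at this position without leaving the scatter: a 1.0-fold higher number from compound 1 to compound 4 (0.00 log units; within the scatter) and a 1.2-fold lower number from compound 2 to compound 4 (0.07 log units; within the scatter). Against 3-methylphenyl the reading is an at least 1.4-fold lower number from compound 3 to compound 4 (0.17 log units; that floor lies within the scatter), so replacing the aromatic ring with a group with no ring also shows no step beyond the scatter. The value of compound 3 is a limit, not a number: the limit of > 50000 nM in this assay, at which 1 of the 4 values shown sits.

From the compounds shown here alone, whether an amine or a carboxylic acid at this position would move this assay beyond the scatter remains open. Going by these compounds, the true distance of compound 3 from the other compounds also remains open.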